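The compounds below may be only part of what the source reports. "The series", "measured", "known", "first", "only" and "open" are said of these compounds alone.

Measured so far:
- compound 1, `Cc1cc(C)c(S(C)(=O)=O)cc1C(=O)N=C(N)N`: 11 nM
- compound 2, `Cc1cc(Sc2cccc(Cl)c2)c(S(C)(=O)=O)cc1C(=O)N=C(N)N`: 37 nM
- compound 3, `Cc1cc(Sc2ccccc2Cl)c(S(C)(=O)=O)cc1C(=O)N=C(N)N`: 14 nM

All three values come from a functional assay for inhibition of sodium/hydrogen exchanger (Oryctolagus cuniculus); a lower number here means a stronger inhibitor, a higher number a weaker inhibitor. Compound 3 holds the second highest of the three numbers; against compound 1 the gap is a 1.3-fold higher number from compound 1 to compound 3 (0.10 log units; within the scatter), and against compound 2 it is a 2.6-fold lower number from compound 2 to compound 3 (0.42 log units; beyond the scatter).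

Compound 4, `Cc1cc(N2CCCC2)c(S(C)(=O)=O)cc1C(=O)N=C(N)N`, is the next step from compound 3: pyrrolidin-1-yl in place of (2-chlorophenyl)sulfanyl on an aromatic carbon. The place is on an aromatic carbon, ortho to a methylsulfonyl group and meta to a methyl group.

The measured steps bear on it only in part. Replacing the methyl group with a (2-chlorophenyl)sulfanyl gave a 1.3-fold higher number from compound 1 to compound 3 (0.10 log units; within the scatter), with (3-chlorophenyl)sulfanyl gave a 3.4-fold higher number from compound 1 to compound 2 (0.53 log units; beyond the scatter). Both aryl sulfides stay close to compound 1, so substitution at this carbon is tolerated across different groups. Pyrrolidin-1-yl is neither a methyl nor an aryl sulfide, so the expected step from compound 3 is modest at most, with no clear direction beyond the scatter: a 1.3-fold higher number from compound 3 to compound 4 (0.11 log units; within the scatter). Compound 4 is therefore estimated at 18 nM in this assay, within 7 nM to 50 nM.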

Compound 4, half-maximal inhibitory concentration: 11 nM
The estimate for compound 4 lay 1.6-fold (0.21 log units) above the measured number; low and high end bracket the measured number.
By their numbers in this assay, from the lowest: compounds 1, 4 and 3 (each within the scatter of the next); then compound 2.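

In this assay this aromatic carbon, ortho to a methylsulfonyl group and meta to a methyl group, now carries a non-aromatic ring holding nitrogen, and replacing the aryl sulfide gives a 1.3-fold lower number from compound 3 to compound 4 (0.10 log units; within the scatter) while replacing methyl gives no change at the digits printed from compound 1 to compound 4 (within the scatter) in the same series. Against the other aryl sulfide the same group gives a 3.4-fold lower number from compound 2 to compound 4 (0.53 log units; beyond the scatter) and so compound 2 is the one exception to a flat picture: among these four compounds the position accepts a methyl, a (2-chlorophenyl)sulfanyl and a pyrrolidin-1-yl with no separation beyond the scatter. Nothing given here accounts for this tolerance or for the separate place of compound 2.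

Open, from the compounds shown here alone, is whether an open-chain amine such as dimethylamino, a morpholine ring or a carboxylic acid on this carbon would stay in the same range. Also open, going by these compounds, is whether a 4-chlorophenyl sulfanyl group would sit with compound 2 or with compound 3.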